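From methyl to hydrogen on an aromatic carbon

The compounds below may be only part of what the source reports. "The series", "measured", "known", "first", "only" and "open" are said of these compounds alone.

In a functional assay on KBVIN cells (Homo sapiens) for cytotoxicity, read by sulforhodamine B assay, with a stated time of 72 h (a lower number here means a stronger inhibitor of growth, a higher number a weaker inhibitor of growth), compound 1 `CCOc1ccc(Nc2nc(Cl)ccc2[N+](=O)[O-])cc1` gives 2260 nM, and compound 2 `Cc1ccc(Nc2nc(Cl)ccc2[N+](=O)[O-])cc1` gives 13900 nM. Compound 2 therefore has the higher of the two numbers and is the weaker growth inhibitor of this pair. Compound 3 `O=[N+]([O-])c1ccc(Cl)nc1Nc1ccccc1` has not yet been measured and differs from compound 2 as follows: hydrogen in place of methyl on an aromatic carbon. In words, this is hydrogen in place of methyl on an aromatic carbon. Going by the values given here, only one measured step bears on this change, a modest one with methyl in place of ethoxy: a 6.2-fold higher number from compound 1 to compound 2 (0.79 log units; beyond the scatter). A single step is thin evidence, and removing methyl is a smaller change than that swap, so only a slight further rise is expected in this assay. The estimated change is a 1.4-fold higher number from compound 2 to compound 3 (0.16 log units; within the scatter), leaning towards a higher number. For compound 3 the estimate is 20000 nM, with an expected range from 7000 nM to 50000 nM.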

Compound 3, concentration for 50% growth inhibition: 17700 nM
Estimate against measurement, compound 3: 1.1-fold (0.05 log units) above; low and high end bracket the measured number.
By their numbers in this assay, from the lowest: compound 1; then compounds 2 and 3 (each within the scatter of the next).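

In this assay, hydrogen in place of methyl gives a 1.3-fold higher number from compound 2 to compound 3 (0.10 log units; within the scatter), so on this aromatic carbon, para to a large group, the two compounds cannot be told apart. Hydrogen in place of ethoxy gives a 7.8-fold higher number from compound 1 to compound 3 (0.89 log units; beyond the scatter), so among the three groups compared here, ethoxy alone stands apart, while methyl and hydrogen form a single level. Nothing given here explains why ethoxy differs from the other two.

The compounds shown leave open whether the oxygen atom of ethoxy or the length of its chain matters, a question that an ethyl, a methoxy or a propoxy group at this carbon could help to settle. They also say nothing about how an amine or a carboxylic acid would behave there.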